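The compounds below may be only part of what the source reports. "The series", "measured", "known", "first", "only" and "open" are said of these compounds alone.

Measured compounds:
Compound 1 `COc1ccc2c(O[C@H]3C[C@H]4C(=O)N(C)CCCC/C=C/[C@@H]5C[C@@]5(C(=O)NS(=O)(=O)C5(C)CC5)NC(=O)N4C3)cc(-c3nc(C(C)C)cs3)nc2c1Cl`: 48500 nM
Compound 2 `COc1ccc2c(O[C@H]3C[C@H]4C(=O)N(C)CCCC/C=C/[C@@H]5C[C@@]5(C(=O)NS(=O)(=O)C5(C)CC5)NC(=O)N4C3)cc(-c3nc(C4CCC4)cs3)nc2c1Cl`: 75000 nM

In an ADME assay on Huh-7 cells (Homo sapiens) for cytotoxicity, read by colorimetric assay (a lower number here means that less compound is tolerated, a higher number that more compound is tolerated), compound 1 gives 48500 nM, while compound 2 gives 75000 nM. Compound 2 sits at the upper end of these two numbers, but the step of a 1.5-fold higher number from compound 1 to compound 2 (0.19 log units; within the scatter) lies within the scatter, so the two compounds cannot be told apart on this assay.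

Compound 3 `COc1ccc2c(O[C@H]3C[C@H]4C(=O)N(C)CCCC/C=C/[C@@H]5C[C@@]5(C(=O)NS(=O)(=O)C5(C)CC5)NC(=O)N4C3)cc(-c3cc(C(C)C)on3)nc2c1Cl` is the next compound in the set. It differs from compound 2 by 5-isopropyl-1,2-oxazol-3-yl in place of 4-cyclobutyl-1,3-thiazol-2-yl on an aromatic carbon. Among the compounds with values here, the only measured step, a 1.5-fold higher number from compound 1 to compound 2 (0.19 log units; within the scatter), concerns a different exchange at the same aromatic carbon and was within the scatter; no measured step touches the exchange of a 4-cyclobutyl-1,3-thiazol-2-yl for a 5-isopropyl-1,2-oxazol-3-yl. Within the data shown here, with only one small step as a guide, the expected change a 1.3-fold lower number from compound 2 to compound 3 (0.10 log units; within the scatter) is none beyond the scatter. Compound 3 is therefore estimated to give 60000 nM in this assay, with a range from 30000 nM to 110000 nM.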

Compound 3, half-maximal cytotoxic concentration: 75000 nM
For compound 3 the middle estimate is 1.3-fold (0.10 log units) below the measured one; the range from low to high includes it.
By their numbers in this assay, from the lowest: compounds 1, 2 and 3 (each within the scatter of the next).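

In this assay, within the data shown here, the earlier pair showed only that the group on the thiazole could change without a reading beyond the scatter; compound 3 extends this to replacing the five-membered aromatic ring itself. With the cyclobutyl-bearing thiazole as the starting point, the exchange gives no change at the digits printed from compound 2 to compound 3 (within the scatter), and with the isopropyl group kept on the incoming ring, it gives a 1.5-fold higher number from compound 1 to compound 3 (0.19 log units; within the scatter). At this aromatic carbon next to the ring nitrogen, a sulfur-containing and an oxygen-containing ring therefore cannot be told apart in this assay.

Going by these compounds, it remains open whether an amine or a carboxylic acid on the ring, or a longer chain in place of isopropyl, would move the number beyond the scatter. Nothing shown offers an explanation for these readings.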